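This account rests on a few compounds, and the source may have more. Where it says the series, first, only, none or still open, it means among the compounds named here.

Notes on the amides built on the core of compound 1 `Cc1ccccc1C(=O)Nc1ncc(-c2ccccc2)n1C`, read in a toxicity assay on THP-1 cells (Homo sapiens) for inhibition; a lower number here means that less compound is tolerated, a higher number that more compound is tolerated. Compound 1 gives > 100000 nM, which is a limit and not a number. Compound 2 `Cc1cccc(C(=O)Nc2ncc(-c3ccccc3)n2C)c1` gives > 50000 nM, again a limit. Compound 3 `Cn1c(-c2ccccc2)cnc1NC(=O)c1ccc(Br)cc1` gives > 100000 nM, so it too stands only at a limit.

The step followed here leads to compound 4 `Cn1c(-c2ccccc2)cnc1NC(=O)c1cccc(Cl)c1`, with this structural change: 3-chlorophenyl in place of 4-bromophenyl on a carbonyl carbon. Among the compounds with values here, three measured steps bear on it, all changes of the group on the same carbonyl carbon: a step that the two limits leave unreadable from compound 1 to compound 2, a step that the two limits leave unreadable from compound 1 to compound 3 and a step that the two limits leave unreadable from compound 2 to compound 3. None of them has a readable size, so they offer no measured size to carry over. No step beyond the scatter is therefore expected in this assay, in either direction.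

The estimated step is a number no higher from compound 3 to compound 4 (the limit leaves the size open). Compound 4 is expected at about 100000 nM, with an expected range from 40000 nM to 200000 nM, and a report as a limit is the likeliest outcome.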

Compound 4, half-maximal cytotoxic concentration: > 50000 nM
Compound 4: a limit, no number; the forecaster's own chance of this, stated with the estimate: 85%; the middle value is on the limit's open side.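

In this assay compound 4 gives > 50000 nM, which is a limit and not a number. Its steps from compound 1, compound 2 and compound 3 therefore cannot be read. The compounds shown leave open whether any of these changes on the carbonyl carbon alters the tolerated concentration at all.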